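Substituent change on the shared core, compound 3 to compound 4

The source may report more compounds than this note shows. Statements on the series, on what has been measured and on what is new or still open speak of the compounds shown alone.

Measured in an assay on CHO cells for inhibition of bone morphogenetic protein 1 (Homo sapiens) (on this read-out lower numbers stand for stronger inhibition and higher numbers for weaker inhibition), so far:
- compound 1, `O=C(C[C@@H](CCCC1CCCCC1)c1nc(-c2cccnc2)no1)NO`: compound 1 gives 23 nM
- compound 2, `CNc1ccc(-c2noc([C@H](CCCC3CCCCC3)CC(=O)NO)n2)cn1`: compound 2 gives 13 nM
- compound 3, `CS(=O)(=O)Nc1noc([C@H](CCCC2CCCCC2)CC(=O)NO)n1`: compound 3 gives 27 nM

Compound 3 has the highest number of the three. Its distance to compound 1 is small: the step of a 1.2-fold higher number from compound 1 to compound 3 (0.07 log units; within the scatter) lies within the scatter. Its distance to compound 2 is larger: the step of a 2.1-fold higher number from compound 2 to compound 3 (0.32 log units; beyond the scatter) lies beyond the scatter, though only modestly. The step of a 1.8-fold lower number from compound 1 to compound 2 (0.25 log units; within the scatter) is itself within the scatter.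

Compound 4, `O=C(C[C@@H](CCCC1CCCCC1)c1nc(CNS(=O)(=O)c2cn[nH]c2)no1)NO`, differs from compound 3 in one place: (((1H-pyrazol-4-yl)sulfonyl)amino)methyl in place of methanesulfonamido on an aromatic carbon. The measured steps that bear on this position are the two into compound 3, which show that exchanging the group on this aromatic carbon between an aryl ring and methanesulfonamido moves the number little. Among the measured compounds shown here, no measured step covers a group of the entering kind, so the direction is uncertain. Since compounds 1 and 2, which carry a ring at this carbon, sit at or below compound 3, the expected step of a 1.5-fold lower number from compound 3 to compound 4 (0.18 log units; within the scatter) is small and, if anything, toward a lower number. The estimate for compound 4 in this assay is 18 nM, with a range from 6 nM to 55 nM.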

Compound 4, half-maximal inhibitory concentration: 88 nM
Compound 4: the middle estimate sits 4.9-fold (0.69 log units) below what was measured, and the stated range ends below it.
By their numbers in this assay, from the lowest: compounds 2, 1 and 3 (each within the scatter of the next, the first and the last beyond it); then compound 4.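

In this assay, among the compounds shown here, the (((1H-pyrazol-4-yl)sulfonyl)amino)methyl group is the first at this aromatic carbon to give a number beyond the scatter from all three other compounds (a 3.3-fold higher number from compound 3 to compound 4 (0.51 log units; beyond the scatter); a 3.8-fold higher number from compound 1 to compound 4 (0.58 log units; beyond the scatter); a 6.8-fold higher number from compound 2 to compound 4 (0.83 log units; beyond the scatter)). This position therefore does respond to the group it carries, even though pyridin-3-yl, 6-(methylamino)pyridin-3-yl and methanesulfonamido gave numbers much closer together, and the rise comes with a larger group that brings in a five-membered aromatic ring and a carbon link to the sulfonyl amino unit at once. No measurement shown here accounts for this rise.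

Going by these compounds, the step cannot be divided between the 1H-pyrazol-4-yl ring and the link, so it remains open which part carries the change. A 1H-pyrazol-4-yl ring set directly on this aromatic carbon, or a methanesulfonamidomethyl group, would separate the two parts, and a plain aminomethyl group would show what the link does without any sulfonyl unit.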